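Exchanging an ethyl for a chloro on the amide aryl

This account rests on a few compounds, and the source may have more. Where it says the series, first, only, none or still open, it means among the compounds named here.

The two measured compounds:
compound 1, `O=C(Nc1ccc(F)cc1)c1cncc(N2CC3CC(C2)N3)c1`, which in an assay on cells for displacement of a labelled ligand from Neuronal acetylcholine receptor; alpha3/beta4 (Homo sapiens) (a lower number here means a stronger inhibitor, a higher number a weaker inhibitor), gives 81 nM
compound 2, `CCc1cccc(NC(=O)c2cncc(N3CC4CC(C3)N4)c2)c1`, which in this assay gives 306 nM

Among these two numbers compound 2 stands highest; its only neighbour is compound 1, and the shift a 3.8-fold higher number from compound 1 to compound 2 (0.58 log units; beyond the scatter) lies beyond the scatter. Compound 3, `O=C(Nc1cccc(Cl)c1)c1cncc(N2CC3CC(C2)N3)c1`, keeps the shared core and the amide and differs from compound 2 only in chloro in place of ethyl on an aromatic carbon. For the measured compounds named here, the single measured step bears on it only loosely: it moved from compound 1 to compound 2 by altering both the substituent and its position on the aryl ring at once, so there is no step that isolates the effect of a chloro at this place. What can be said is that a halogen-bearing aryl in compound 1 gave the lower number, while the ethyl-bearing aryl in compound 2 gave the higher one. On that basis a modest decrease, a 1.9-fold lower number from compound 2 to compound 3 (0.28 log units; within the scatter), is expected, without confidence that it clears the scatter. Compound 3 is estimated at 160 nM, with a range from 50 nM to 500 nM.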

Compound 3, inhibition constant: 59 nM
Compound 3: middle estimate off by 2.7-fold (0.43 log units), on the high side, within the range that was stated.
By their numbers in this assay, from the lowest: compounds 3 and 1 (each within the scatter of the next); then compound 2.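

Holding the place on the ring fixed and changing only the substituent, the swap of ethyl for chloro in this assay gives a 5.2-fold lower number from compound 2 to compound 3 (0.71 log units; beyond the scatter) and thus isolates what the earlier step could not, since that step changed the group and its place together. The comparison with the fluorinated compound gives a 1.4-fold lower number from compound 1 to compound 3 (0.14 log units; within the scatter) so the 3-chlorophenyl and 4-fluorophenyl amides cannot be told apart here, and among these three compounds only compound 2 stands apart. A substituent at this place on the ring therefore does not by itself go with the higher number, as compound 3 carries its chloro where compound 2 carries its ethyl. The data shown offer no explanation for the difference between chloro and ethyl at this place.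

Between compound 1 and compound 3 the halogen and its place on the ring change together, so the contribution of each remains unresolved. The compounds shown also leave open how a methyl, a methoxy group, a nitrile or an amine at this place would compare with the chloro and the ethyl.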